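The source may hold more compounds than are shown below. What is called first, only, known or untested is meant among the compounds shown, and "the series" means these compounds.

Measured compounds:
Compound 1, `COc1cc(-c2nn(-c3cccc(NC(=O)Nc4cc(C(F)(F)F)cc(C(F)(F)F)c4)c3)cc2-c2ccncc2)ccc1Cl`, gives 5720 nM.
Compound 2, `COc1cc(-c2nn(-c3cccc(NC(=O)c4cccc(C(F)(F)F)c4)c3)cc2-c2ccncc2)ccc1Cl`, gives > 50000 nM.
Compound 3, `O=C(Nc1cccc(-n2cc(-c3ccncc3)c(-c3ccc(Cl)c(O)c3)n2)c1)Nc1cc(C(F)(F)F)cc(C(F)(F)F)c1`, gives 5270 nM.

All three were tested in a functional assay on ACHN cells (Homo sapiens) for inhibition, read by sulforhodamine B assay, with a stated time of 48 h; a higher number here means a weaker inhibitor of growth, a lower number a stronger inhibitor of growth. The value for compound 2 is a limit of the assay, not a number; it sits at the limit of > 50000 nM in this assay, at which 1 of the 3 values shown sits, so compound 2 stands at the weak end of everything shown. Compound 4, `COc1cc(-c2nn(-c3cccc(NC(=O)c4ccccc4)c3)cc2-c2ccncc2)ccc1Cl`, has not yet been measured. It differs from compound 2 by hydrogen in place of trifluoromethyl on an aromatic carbon. Among the measured compounds shown here, the only measured step, a 1.1-fold lower number from compound 1 to compound 3 (0.04 log units; within the scatter), concerns another part of the shared core and does not bear on this change. With compound 2 already at a limit, compound 4 is expected to stay there, with an expected step that the limit leaves unreadable from compound 2 to compound 4. The estimate for compound 4 is 60000 nM, with a range from 20000 nM to 200000 nM.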

Compound 4, concentration for total growth inhibition: > 100000 nM
Compound 4 gave a limit, no number; the forecaster's own chance of this, stated with the estimate: 70%; middle value at least 1.6-fold (0.22 log units) away from the limit.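

Compound 2 and compound 4 both give limits of the assay rather than numbers, so the step between them cannot be read. The compounds shown leave open whether swapping trifluoromethyl for hydrogen changes growth inhibition at all.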